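The source may report more compounds than this note shows. Statements on the series, on what has been measured and on what is new or still open speak of the compounds shown alone.

Measured so far in a functional assay on MCF7 cells (Homo sapiens) for inhibition, read by CCK-8 assay, with a stated time of 48 h; on this read-out lower numbers stand for stronger inhibition and higher numbers for weaker inhibition:
Compound 1 `COc1cc(-c2ccnc3cc(-c4ccc5cc[nH]c5c4)nn23)cc(OC)c1OC` — compound 1 gives 23 nM
Compound 2 `COc1ccc(-c2cc3nccc(-c4cc(OC)c(OC)c(OC)c4)n3n2)cc1F` — compound 2 gives 183 nM

Compound 2 stands at the higher of the two numbers; its nearest neighbour is compound 1, with an 8.0-fold higher number from compound 1 to compound 2 (0.90 log units; beyond the scatter) on swapping the aryl at this position. Compound 3 `COc1cc(-c2ccnc3cc(-c4ccc(N(C)C)cc4)nn23)cc(OC)c1OC` carries 4-(dimethylamino)phenyl in place of 3-fluoro-4-methoxyphenyl on an aromatic carbon. For the measured compounds named here, no measured step covers this exact swap; only the step from compound 1 to compound 2 shows that the aryl here moves this assay by a modest amount. Compound 3 is expected to land between the two, a 2.3-fold lower number from compound 2 to compound 3 (0.36 log units; beyond the scatter), estimated at 80 nM with a range of 20 nM to 400 nM.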

Compound 3, half-maximal inhibitory concentration: 44 nM
Beside the measured number, compound 3's estimate is 1.8-fold (0.26 log units) above it; low and high end bracket the measured number.
By their numbers in this assay, from the lowest: compounds 1 and 3 (each within the scatter of the next); then compound 2.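

In this assay, the step of a 4.2-fold lower number from compound 2 to compound 3 (0.62 log units; beyond the scatter) shows that this aromatic carbon also responds to a change between two substituted phenyl rings, not only to a change from 1H-indol-6-yl. The step of a 1.9-fold higher number from compound 1 to compound 3 (0.28 log units; within the scatter) does not separate 4-(dimethylamino)phenyl from 1H-indol-6-yl, so a low number here is not tied to the 1H-indol-6-yl group. Nothing available explains these differences.

Still open, as far as these compounds go, is whether the fluorine or the methoxy of compound 2 goes with its higher number, which 3-fluorophenyl and 4-methoxyphenyl would test. Whether 4-aminophenyl or 4-(morpholin-4-yl)phenyl would match 4-(dimethylamino)phenyl also remains unresolved.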